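A few compounds are considered here, and "the series" means these few. Any claim that something is new, unique, unknown or untested is made for them only; others in the source may bear on it.

Three compounds have been measured in an assay on HEK293 cells for positive allosteric modulation of metabotropic glutamate receptor 2 (Rattus norvegicus), read by thallium flux, with a stated time of 2.5 min; a lower number here means a smaller maximal response, a higher number a larger maximal response:

compound 1 `COc1cc(C(=O)O)ccc1OCCCCOc1ccc(C(=O)C(C)C)c(O)c1C`: 73.1%
compound 2 `CCC(=O)c1ccc(OCCCCOc2cc(C(=O)O)ccc2OC)c(C)c1O`: 72.6%
compound 3 `Cc1c(OCCCCOc2ccc(C(=O)O)cc2)ccc(C(=O)CC(C)C)c1O`: 88%

Compound 2 shows the smallest of the three numbers, but its value and that of compound 1 lie within the scatter of each other, so the two cannot be told apart. Compound 3 reads higher than compound 2 by a gap beyond the scatter.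

Compound 4 `COc1ccc(C(=O)O)cc1OCCCCOc1ccc(C(=O)CC(C)C)c(O)c1C` has not been measured. It differs from compound 2 in one place: isopropyl in place of methyl on a saturated chain carbon bound to a carbonyl carbon. For the measured compounds named here, no directly comparable pair of measured compounds is available, so the size of this step is uncertain. Compound 3, which also carries the larger ketone chain, gives 88%, and on that ground a modest upward step is expected, a number 8.4 percentage points higher from compound 2 to compound 4 (within the scatter), close to the edge of the scatter. Compound 4 is therefore estimated at 81%, with a range from 70% to 92%.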

Compound 4, largest response reached (reported as percent of maximum), in percent of the reference or control that the assay uses: 89.7%
The estimate for compound 4 lay 8.7 percentage points below the measured number; low and high end bracket the measured number.
By their numbers in this assay, from the lowest: compounds 2 and 1 (each within the scatter of the next); then compounds 3 and 4 (each within the scatter of the next).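

In this assay the change from propanoyl to isobutylcarbonyl gives a number 17.1 percentage points higher from compound 2 to compound 4 (beyond the scatter). For the compounds shown here, this is the first comparison here that differs in one place only, and it shows that the maximal response can respond to the end of this ketone chain: isopropyl in place of methyl moves the number by more than repeat measurements would. Nothing shown here explains this gain. As far as these compounds go, it remains open whether ethyl, a longer chain such as pentyl, or a cyclohexyl ring at this place would give a similar response, and whether the same step holds on other cores.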